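From Isobutyl to Cyclobutylmethyl: One Step in Acid Dissociation

A few compounds are considered here, and "the series" means these few. Any claim that something is new, unique, unknown or untested is made for them only; others in the source may bear on it.

The measured compounds:
compound 1, `Brc1ccc(N(CC2CC2)C2=NCCN2)c(Br)c1`, 11.2
compound 2, `Brc1cccc(N(CC2CC2)C2=NCCN2)c1Br`, 11.1
compound 3, `CC(C)CN(C1=NCCN1)c1c(Br)cccc1Br`, 11

In a physicochemical assay for acid dissociation, compound 3 gives the lowest of the three numbers, yet its gap to compound 2, the nearest, and to compound 1, the furthest, both lie within the scatter, so the three read as one value. The unmeasured compound 4, `Brc1cccc(Br)c1N(CC1CCC1)C1=NCCN1`, is reached from compound 3 by cyclobutyl in place of isopropyl on a saturated chain carbon bound to a nitrogen on an aromatic ring. Among the measured compounds shown here, with no step between measured compounds to lean on, and the three values so close, the account expects no shift beyond the scatter in this assay, in neither direction. The step from compound 3 to compound 4 is therefore estimated as no change at the digits printed from compound 3 to compound 4 (within the scatter). Compound 4 is expected to give 11, within 10.7 to 11.3.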

Compound 4, acid dissociation constant: 10.9
Compound 4: the middle estimate sits 0.10 log units above what was measured; measured number inside the range.
By their numbers in this assay, from the lowest: compounds 4, 3, 2 and 1 (each within the scatter of the next).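

In this assay, among the compounds shown here, cyclobutyl in place of isopropyl on a saturated chain carbon bound to a nitrogen on an aromatic ring gives a number 0.10 log units lower from compound 3 to compound 4 (within the scatter), the first step that can be read at this position. It shows that this change, which brings in a four-membered ring of carbon, does not carry the number beyond the scatter. No measurement shown bears on what lies behind this step. Going by these compounds, whether an amine, a carboxylic acid or a longer chain in this place would move the number beyond the scatter stays open. So does whether cyclobutyl would read alike on the core of compound 1.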